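Series notes: chloro added to compound 1

A few compounds are considered here, and "the series" means these few. Any claim that something is new, unique, unknown or untested is made for them only; others in the source may bear on it.

In a functional assay on MCF7 cells (Homo sapiens) for cytotoxicity, read by MTT assay, with a stated time of 24 h (a lower number here means a stronger inhibitor, a higher number a weaker inhibitor), compound 1 (`CC(=O)Nc1ccc(Oc2cccc3c(NC(=O)Nc4cccc(C(F)(F)F)c4)cccc23)cc1`) gives 953 nM and stands level with compound 2 (`O=C(Nc1cccc(C(F)(F)F)c1)Nc1cccc2c(Oc3ccc([N+](=O)[O-])cc3)cccc12`) at 953 nM and compound 3 (`O=C(Nc1ccccc1)Nc1cccc2c(Oc3ccc([N+](=O)[O-])cc3)cccc12`) at 953 nM on these numbers. Compound 4 (`CC(=O)Nc1ccc(Oc2cccc3c(NC(=O)Nc4ccc(Cl)c(C(F)(F)F)c4)cccc23)cc1`) differs from compound 1 by one change (chloro in place of hydrogen on an aromatic carbon), chloro in place of hydrogen on an aromatic carbon. The closest evidence, on the same aromatic ring, is hydrogen in place of trifluoromethyl with no change at the digits printed from compound 2 to compound 3 (within the scatter) in the read-out. Nitro in place of acetamido on another ring gave no change at the digits printed from compound 1 to compound 2 (within the scatter) as well. Neither step tests a chloro group, so no step beyond the scatter is expected in this assay and no direction is favoured. The estimated change is a 1.1-fold lower number from compound 1 to compound 4 (0.02 log units; within the scatter) as expected from these steps. For compound 4 the expected half-maximal inhibitory concentration is 900 nM with an estimated range of 400 nM to 1900 nM in this series.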

Compound 4, half-maximal inhibitory concentration: 953 nM
Estimate against measurement, compound 4: 1.1-fold (0.02 log units) below, within the range that was stated.
By their numbers in this assay, from the lowest: compounds 1, 2, 3 and 4 (each within the scatter of the next).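

Chloro in place of hydrogen, ortho to the trifluoromethyl group, gives no change at the digits printed from compound 1 to compound 4 (within the scatter) in this assay. Going by these compounds alone, this adds a direct reading at this position of the ring, where the earlier steps covered only the trifluoromethyl group and the group on the other ring: a chlorine atom here produces no step beyond the scatter. No further data bear on this result.

As far as these compounds go, whether an amine, a carboxylic acid or a longer chain at this position would shift the read-out stays open, as does the effect of chloro with trifluoromethyl replaced by hydrogen.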